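Swapping a side chain at the assay limit

The source may report more compounds than this note shows. Statements on the series, on what has been measured and on what is new or still open speak of the compounds shown alone.

Measured in a functional assay on NALM-6 cells (Homo sapiens) for cytotoxicity, with a stated time of 72 h; a lower number here means that less compound is needed, a higher number that more compound is needed for the effect; each value is a limit of the assay, not a number:
- compound 1 `C=C[C@@](C)(/C=C/c1ccc(OC)cc1)CCC=C(C)C`: > 43400 nM
- compound 2 `C=C[C@@](C)(/C=C/c1ccc(OCc2ccccc2)cc1)CCC=C(C)C`: > 43400 nM
- compound 3 `C=C[C@@](C)(/C=C/c1ccc(O)cc1)CCC(O)C(C)(C)O`: > 43400 nM

Compound 3 has only a limit to its name, > 43400 nM. It therefore offers no exact starting point, and the wider picture is the limit of > 43400 nM in this assay, at which 3 of the 3 values shown sit.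

The next structure is compound 4 `C=C[C@@](C)(/C=C/c1ccc(O)cc1)CC/C=C/C(=O)OCC`. The change from compound 3 is 2-(ethoxycarbonyl)ethenyl in place of 1,2-dihydroxy-2-methylpropyl on a saturated chain carbon, three bonds along the chain from two double-bonded chain carbons. In words, 2-(ethoxycarbonyl)ethenyl replaces 1,2-dihydroxy-2-methylpropyl.

Among the compounds with values here, only one measured step exists, a step that the two limits leave unreadable from compound 1 to compound 2. It concerns a different place in the molecule and has no readable size, so it gives neither a size nor a direction to carry over. The expectation therefore rests on the limit alone, and a further limit in this assay is quite possible. If a number does appear, only a modest move toward less compound needed is expected because of the limit of > 43400 nM in this assay, at which 3 of the 3 values shown sit. The expected change is an at least 1.4-fold lower number from compound 3 to compound 4 (0.16 log units; that floor lies within the scatter). For compound 4 the estimated value is 30000 nM, with an expected range of 10000 nM to 60000 nM.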

Compound 4, half-maximal effective concentration: > 43400 nM
Compound 4 ended at the assay's limit; the forecaster's own chance of this, stated with the estimate: 55%; middle value at least 1.4-fold (0.16 log units) from the limit.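

In this assay compound 4 gives > 43400 nM, a limit of the assay and not a number. Within the data shown here, compound 3 also has only a limit, so no step between compound 3 and compound 4 can be read. Open is what structure would give a real number, since the compounds shown offer only this: the limit of > 43400 nM in this assay, at which 4 of the 4 values shown sit.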